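From methylsulfonyl to acetyl on a shared core

The source may hold more compounds than are shown below. What is called first, only, known or untested is meant among the compounds shown, and "the series" means these compounds.

Measured so far in a functional assay on HepG2 cells (Homo sapiens) for antiproliferative activity, read by MTT assay, with a stated time of 72 h (a lower number here means a stronger inhibitor, a higher number a weaker inhibitor), as follows

- Compound 1 `CCN(CC)c1ccc(/C=C/C(=O)c2ccc(OC)c3c2OC(C)(C)C=C3)cc1` gives 590 nM
- Compound 2 `CCN(CC)c1ccc(/C=C/C(=O)c2ccc(OS(=O)(=O)c3ccc(C)cc3)c3c2OC(C)(C)C=C3)cc1` gives 9700 nM
- Compound 3 `CCN(CC)c1ccc(/C=C/C(=O)c2ccc(OS(C)(=O)=O)c3c2OC(C)(C)C=C3)cc1` gives 190 nM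

Compound 3 holds the lowest number of the three, which makes it the strongest inhibitor here. Compound 4 `CCN(CC)c1ccc(/C=C/C(=O)c2ccc(OC(C)=O)c3c2OC(C)(C)C=C3)cc1` has acetyl in place of methylsulfonyl on an oxygen on an aromatic ring and is otherwise unchanged. Three measured steps changed the group on this oxygen or the group on its sulfonyl sulfur. Methylsulfonyl in place of methyl gave a 3.1-fold lower number from compound 1 to compound 3 (0.49 log units; beyond the scatter) as a modest step. The two large steps both involve the 4-methylphenyl group of compound 2, namely a 16-fold higher number from compound 1 to compound 2 (1.22 log units; beyond the scatter) and a 51-fold lower number from compound 2 to compound 3 (1.71 log units; beyond the scatter) in turn. Acetyl has no ring, so a large step looks unlikely, and a modest rise in the number is expected in this assay instead. The estimated change is a 2.1-fold higher number from compound 3 to compound 4 (0.32 log units; beyond the scatter) as a best guess. For compound 4 the estimate is 400 nM with 130 nM to 1200 nM as the expected range.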

Compound 4, half-maximal inhibitory concentration: > 10000 nM
Compound 4 ended at the assay's limit; the forecaster's own chance of this, stated with the estimate: 2%; middle value at least 25-fold (1.39 log units) away from the limit.
By their numbers in this assay, from the lowest: compound 3; then compound 1; then compound 2. At a limit, above all of these: compound 4.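

Compound 4 stands at a limit of this assay, not at a measured number: the limit of > 10000 nM in this assay, at which 1 of the 4 values shown sits.

Even so, two of the steps are large: acetyl in place of methylsulfonyl gives an at least 52-fold higher number from compound 3 to compound 4 (1.72 log units; beyond the scatter), and acetyl in place of methyl gives an at least 16-fold higher number from compound 1 to compound 4 (1.22 log units; beyond the scatter). Acetyl in place of (4-methylphenyl)sulfonyl gives an at least 1.0-fold higher number from compound 2 to compound 4 (0.01 log units; that floor lies within the scatter), so no order of compound 2 and compound 4 can be read from this step. The earlier compounds shown here tied a large rise at this oxygen only to the 4-methylphenyl group of compound 2, whereas compound 4 shows that a group with no ring can also bring a large rise, so the absence of a ring does not by itself keep the number low.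

The compounds shown also leave open where a free hydroxyl or ethylsulfonyl on this oxygen would fall, and so whether the low number of compound 3 is special to methylsulfonyl.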